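Working notes: aryl swap on compound 2

This account rests on a few compounds, and the source may have more. Where it says the series, first, only, none or still open, it means among the compounds named here.

Values from a functional assay on RKO cells (Homo sapiens) for cytotoxicity, read by resazurin assay, with a stated time of 72 h (on this read-out higher numbers stand for weaker inhibition and lower numbers for stronger inhibition), are as follows:
- compound 1 `Cc1cn(-c2csc(Nc3ccc(Br)cc3)n2)c(C)n1` gives 400 nM
- compound 2 `Cc1nc2ccccc2n1-c1csc(Nc2cccc(Br)c2)n1` gives 36000 nM
- compound 3 `Cc1nccn1-c1csc(Nc2cccc(Br)c2)n1` gives > 100000 nM (a limit, not a number)

Compound 2 holds the higher of the two numeric values, and the gap down to compound 1 lies beyond the scatter. Compound 3 has only a limit.

The next compound to be tested, compound 4 `COc1ccc(Nc2nc(-n3c(C)nc4ccccc43)cs2)cc1`, keeps the rest of compound 2 and carries 4-methoxyphenyl in place of 3-bromophenyl on a nitrogen on an aromatic ring. Among the measured compounds shown here, no measured pair isolates this change. Compound 1 and compound 2 differ in more than one place, so the value of compound 1 (400 nM) offers only loose support for a move towards stronger inhibition. An estimated step (a 6.0-fold lower number from compound 2 to compound 4 (0.78 log units; beyond the scatter)) is expected in this assay to point downward, moderately beyond the scatter. For compound 4 the estimated value is 6000 nM, with an expected range from 1000 nM to 40000 nM.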

Compound 4, half-maximal inhibitory concentration: 25 nM
Compound 4: the middle estimate sits 240-fold (2.38 log units) above what was measured; the measured number lies below the stated range.
By their numbers in this assay, from the lowest: compound 4; then compound 1; then compound 2. At a limit, above all of these: compound 3.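

In this assay, among the compounds shown here, 4-methoxyphenyl in place of 3-bromophenyl gives a 1400-fold lower number from compound 2 to compound 4 (3.16 log units; beyond the scatter), and this is the first measured pair that isolates a change at this place, on a nitrogen on an aromatic ring, with the rest of the structure held. For the compounds shown here, the read-out is thus highly sensitive to the group at this place, which the earlier compounds could only hint at, since compound 1 and compound 2 differ in more than one place. The change alters both the substituent and its ring number at once, and nothing shown accounts for the size of the step.

Going by these compounds, it remains open which of these two alterations carries the step. On these data alone, it is also open whether an amine, or ethoxy as a longer chain in place of methoxy, would hold the value of compound 4 at this place.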